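What an Added Phenyl May Do to Compound 2

This account rests on a few compounds, and the source may have more. Where it says the series, first, only, none or still open, it means among the compounds named here.

- compound 1 `Nc1ccccc1NC(=O)CCCCCN(CC(=O)NCc1ccccc1)C(=O)c1cccc2ccccc12` gives 11000 nM
- compound 2 `Cc1cc(C)cc(C(=O)N(CCCCCC(=O)Nc2ccccc2N)CC(=O)NCc2ccccc2)c1` gives 13700 nM
- compound 3 `Cc1cc(C)cc(C(=O)N(CCCCCC(=O)Nc2cc(-c3ccccc3)ccc2N)CC(=O)NCc2ccccc2)c1` has no measurement yet

In a functional assay on CAL-27 cells (Homo sapiens) for cytotoxicity, read by MTT assay, with a stated time of 72 h (on this read-out higher numbers stand for weaker inhibition and lower numbers for stronger inhibition), compound 2 gives 13700 nM and stands level with compound 1 at 11000 nM so the two cannot be ranked. The change that leads to compound 3 is phenyl in place of hydrogen on an aromatic carbon and it puts phenyl in place of hydrogen on an aromatic carbon, para to an amino group. For the measured compounds named here, only one measured step exists, a 1.2-fold higher number from compound 1 to compound 2 (0.10 log units; within the scatter) and it concerns a group on a carbonyl carbon, not this aromatic carbon. That step was small, but it is a poor guide here, since the new change happens at a different place. Going by the values given here, a whole added ring could matter more than that swap, yet nothing measured so far fixes a direction. A modest lean toward stronger inhibition is a loose judgement, and a result within the scatter would not surprise. The expected step of a 2.1-fold lower number from compound 2 to compound 3 (0.32 log units; beyond the scatter) is therefore modest and uncertain. For compound 3 the estimated value is 6500 nM (1800 nM to 20000 nM) in this cell test.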

Compound 3, half-maximal inhibitory concentration: 18900 nM
The estimate for compound 3 lay 2.9-fold (0.46 log units) below the measured number, and the stated range covers the measured number.
By their numbers in this assay, from the lowest: compounds 1, 2 and 3 (each within the scatter of the next).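

In this assay, putting phenyl in place of hydrogen on the aromatic carbon para to an amino group gives a 1.4-fold higher number from compound 2 to compound 3 (0.14 log units; within the scatter) and so shows that this carbon can carry a whole extra ring with no readable shift in the number. For the compounds shown here, this is the first view of this position, as the earlier step of a 1.2-fold higher number from compound 1 to compound 2 (0.10 log units; within the scatter) concerned a group on a carbonyl carbon, and the two steps together show changes at two different places that both stay within the usual variation between repeat measurements. Nothing measured alongside these numbers offers an explanation for the result.

From the compounds shown here alone, a single added group cannot show how this carbon responds in general, so it remains open whether a small fluorine atom, a carboxylic acid or a pyridine ring there would move the number clearly in either direction. It is equally open whether phenyl at this carbon would behave the same way in the compound that carries naphthalen-1-yl on the carbonyl carbon, since the step shown here starts from the 3,5-dimethylphenyl compound.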